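A few compounds are considered here, and "the series" means these few. Any claim that something is new, unique, unknown or untested is made for them only; others in the source may bear on it.

Going by the values given here, in a functional assay on MIA PaCa-2 cells (Homo sapiens) for inhibition, read by MTT assay, with a stated time of 7 days (on this read-out higher numbers stand for weaker inhibition and lower numbers for stronger inhibition), compound 2 `CCCN(CCC)S(=O)(=O)c1ccc(S(=O)(=O)N2CCC[C@@H](C(=O)OCC)C2)cc1` gives 2300 nM, the higher of the two numbers measured so far. Compound 1 `CCN(CC)S(=O)(=O)c1ccc(S(=O)(=O)N2CCC[C@@H](C(=O)N[C@@H]3CCN(C(=O)OC(C)(C)C)C3)C2)cc1` gives 200 nM in this assay, a gap that lies well beyond the usual scatter. Compound 3 `CCOC(=O)[C@@H]1CCCN(S(=O)(=O)c2ccc(S(=O)(=O)N3CCOCC3)cc2)C1` differs from compound 2 by morpholin-4-yl in place of dipropylamino on a sulfonyl sulfur. Among the compounds with values here, no measured pair shows this exchange on its own, so there is no step to lean on. The expected step in this assay is estimated as a 1.1-fold higher number from compound 2 to compound 3 (0.04 log units; within the scatter), which is not beyond the scatter. Compound 3 is therefore expected to give about 2500 nM, within a range from 800 nM to 8000 nM.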

Compound 3, half-maximal inhibitory concentration: 23500 nM
Beside the measured number, compound 3's estimate is 9.4-fold (0.97 log units) below it; measured number above the stated range.
By their numbers in this assay, from the lowest: compound 1; then compound 2; then compound 3.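

Going by these compounds alone, on a sulfonyl sulfur whose other neighbour is aromatic carbon, the group matters in this assay: morpholin-4-yl in place of dipropylamino gives a 10-fold higher number from compound 2 to compound 3 (1.01 log units; beyond the scatter), the first single-place change that can be read here. The step shows that this position does not tolerate every amine group equally, although the exchange alters the heavy-atom count only slightly. Nothing measured here accounts for the step.

On these data alone, it remains open whether piperidin-1-yl or dibutylamino on that sulfur would give a number closer to compound 2 or to compound 3. As far as these compounds go, whether the same exchange has a similar effect in compound 1 also remains open.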